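This account rests on a few compounds, and the source may have more. Where it says the series, first, only, none or still open, it means among the compounds named here.

Measured compounds in a functional assay (aorta) with Rattus norvegicus as the target; on this read-out lower numbers stand for an effect already at smaller amounts and higher numbers for an effect only at larger amounts of compound:

compound 1 `CC1(C)CC(NC(=O)Nc2ccccc2)c2cc(F)ccc2O1`: 17100 nM
compound 2 `CC1(C)CC(NC(=O)Nc2ccccc2)c2cc(Br)ccc2O1`: 2300 nM
compound 3 `COc1cccc(NC(=O)NC2CC(C)(C)Oc3ccc(F)cc32)c1`: > 10000 nM, a limit of the assay, not a number

Within the data shown here, compound 3 stands only at a limit in this assay; it is the one value of the three that sits at the limit of > 10000 nM in this assay, at which 1 of the 3 values shown sits. The step to it, a step that the limit leaves unreadable from compound 1 to compound 3, therefore cannot be sized.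

Compound 4 `COc1cccc(NC(=O)NC2CC(C)(C)Oc3ccc(Br)cc32)c1` differs from compound 3 by bromo in place of fluoro on an aromatic carbon. The same exchange has been measured once in the series: a 7.4-fold lower number from compound 1 to compound 2 (0.87 log units; beyond the scatter), a modest step to a lower number that lies beyond the scatter. Whether compound 3 sits close to its limit or far beyond it is not known, so the starting point for compound 4 is itself uncertain.

Carrying the size of the step from compound 1 to compound 2 over to compound 3, a step of an at least 2.0-fold lower number from compound 3 to compound 4 (0.30 log units; that floor lies within the scatter) is expected, toward a lower number in this assay. Compound 4 is accordingly estimated at 5000 nM, with a range from 1500 nM to 20000 nM, the wide range reflecting that compound 3 is known only as a limit.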

Compound 4, half-maximal effective concentration: > 10000 nM
Compound 4: only a limit was reported; the forecaster's own chance of this, stated with the estimate: 30%; at least 2.0-fold (0.30 log units) between middle value and limit.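

In this assay, methoxy in place of hydrogen on an aromatic carbon now has a readable size in the bromo pair, an at least 4.3-fold higher number from compound 2 to compound 4 (0.63 log units; beyond the scatter), whereas the same exchange in the fluoro pair could not be sized. The result for compound 4 is a limit and not a number, as is the result for compound 3, so the step between them cannot be read. The lower number seen with bromo in place of fluoro therefore remains shown only for compound 1 and compound 2, and the methoxy pair adds no size for that exchange: the limit of > 10000 nM in this assay, at which 2 of the 4 values shown sit.

Still open, from the compounds shown here alone, is how far compound 3 and compound 4 lie past their limits, and so whether bromo in place of fluoro changes the read-out once methoxy is present. Also open, going by these compounds, is how an amine or a carboxylic acid in place of methoxy would read out.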